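The source may report more compounds than this note shows. Statements on the series, on what has been measured and on what is new or still open speak of the compounds shown alone.

Three compounds have so far been measured in a functional assay on NCI-H460 cells (Homo sapiens) for antiproliferative activity, read by MTT assay, with a stated time of 72 h; a lower number here means a stronger inhibitor, a higher number a weaker inhibitor:

Compound 1 `CN(C)CCn1cnnc1-c1cc(Oc2ccc(NC(=O)Nc3ccc(Cl)c(C(F)(F)F)c3)cc2F)ccn1` gives 1150 nM.
Compound 2 `CN(C)CCn1cnnc1-c1cc(Oc2ccc(NC(=O)Nc3ccc(F)c(F)c3)cc2F)ccn1` gives 9050 nM.
Compound 3 `CN(C)CCn1cnnc1-c1cc(Oc2ccc(NC(=O)Nc3ccc(F)c(Cl)c3)cc2F)ccn1` gives 1580 nM.

Compound 1 stands lowest of the three numbers. Its nearest neighbour is compound 3, with a 1.4-fold higher number from compound 1 to compound 3 (0.14 log units; within the scatter), a difference that lies within the scatter, so the two cannot be ordered. The furthest is compound 2, with a 7.9-fold higher number from compound 1 to compound 2 (0.90 log units; beyond the scatter), a step beyond the scatter. Between the other two there is a 5.7-fold lower number from compound 2 to compound 3 (0.76 log units; beyond the scatter), also beyond the scatter.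

Compound 4 `CN(C)CCCn1cnnc1-c1cc(Oc2ccc(NC(=O)Nc3ccc(Cl)c(C(F)(F)F)c3)cc2F)ccn1` differs from compound 1 only on the chain carried by the triazole: (dimethylamino)methyl in place of dimethylamino on a saturated chain carbon, two bonds along the chain from an aromatic nitrogen. None of the three measured steps bears on this change. Each of them alters the aryl group on the urea nitrogen or a single substituent on that ring, while the chain on the triazole stays the same in all three compounds. The data therefore give no ground for expecting a step in this assay in either direction beyond the scatter, and the expectation is that compound 4 stays close to compound 1.

On that basis compound 4 is estimated at 1200 nM in this assay, with a range from 400 nM to 3600 nM. The expected step is a 1.0-fold higher number from compound 1 to compound 4 (0.02 log units; within the scatter).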

Compound 4, half-maximal inhibitory concentration: 1680 nM
Estimate against measurement, compound 4: 1.4-fold (0.15 log units) below; the measured number falls inside the stated range.
By their numbers in this assay, from the lowest: compounds 1, 3 and 4 (each within the scatter of the next); then compound 2.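

In this assay, within the data shown here, the one step at this position, a 1.5-fold higher number from compound 1 to compound 4 (0.16 log units; within the scatter), shows that 3-(dimethylamino)propyl in place of 2-(dimethylamino)ethyl on the triazole leaves compound 4 indistinguishable from compound 1. The earlier compounds shown here varied only the aryl group on the urea nitrogen, where the number could move beyond the scatter, as in a 7.9-fold higher number from compound 1 to compound 2 (0.90 log units; beyond the scatter), and they said nothing about the chain; this single pair now shows that, with the 4-chloro-3-(trifluoromethyl)phenyl group in place, the chain can carry the extra carbon without a step beyond the scatter. No available evidence bears on how this result comes about.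

On these data alone, it remains open whether a shorter chain such as (dimethylamino)methyl, or one longer than 3-(dimethylamino)propyl, would also stay within the scatter of compound 1, and whether a morpholine or a carboxylic acid could stand at the end of the chain in place of the dimethylamino group. As far as these compounds go, it is also open whether the longer chain would behave the same way alongside the 3,4-difluorophenyl or 3-chloro-4-fluorophenyl groups on the urea nitrogen.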